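Replacing the 3-Methoxyazetidin-1-yl Group: Expected Oral Bioavailability

This account rests on a few compounds, and the source may have more. Where it says the series, first, only, none or still open, it means among the compounds named here.

Measured so far:
- Compound 1, `CCn1c(-c2cnc(C)nc2)nc2c(O[C@H]3CCN(C(=O)C4CC4)C3)ncnc21`, gives 100% in an ADME assay on the whole organism (Canis lupus familiaris, strain Beagle) for pharmacokinetics; on this read-out higher numbers stand for higher oral bioavailability and lower numbers for lower oral bioavailability.
- Compound 2, `CCn1c(-c2ccc(C(F)(F)F)nc2)nc2c(O[C@H]3CCN(C(=O)c4cocn4)C3)ncnc21`, gives 100% in this assay.
- Compound 3, `CCn1c(-c2ccc(C(F)(F)F)nc2)nc2c(O[C@H]3CCN(C(=O)N4CC(OC)C4)C3)ncnc21`, gives 100% in this assay.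

All three measured compounds share one core and differ only in the group on the carbonyl carbon attached to the amide-type nitrogen in the ring, and in the substituent on the pendant aromatic ring. On this assay compound 3 stands level with compound 1 and compound 2; the step of no change at the digits printed from compound 2 to compound 3 (within the scatter) lies within the scatter, so none of the three can be called better or worse than another.

The unmeasured compound 4, `CCn1c(-c2ccc(C(F)(F)F)nc2)nc2c(O[C@H]3CCN(C(=O)C4CCOC4)C3)ncnc21`, differs from compound 3 in a single place: oxolan-3-yl in place of 3-methoxyazetidin-1-yl on a carbonyl carbon. Among the compounds with values here, the one step that bears on this carbonyl position, no change at the digits printed from compound 2 to compound 3 (within the scatter), shows no change, and compound 1, which also carries a carbon ring on that carbonyl, gives 100%. The step of a number 5 percentage points lower from compound 3 to compound 4 (within the scatter) is therefore expected to stay within the scatter. For compound 4 the estimate on this assay is 95%, with a range from 75% to 100%.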

Compound 4, oral bioavailability: 100%
Beside the measured number, compound 4's estimate is 5 percentage points below it, and the stated range covers the measured number.
By their numbers in this assay, from the lowest: compounds 1, 2, 3 and 4 (each within the scatter of the next).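

With the rest of the molecule held the same, oxolan-3-yl in place of 3-methoxyazetidin-1-yl on the carbonyl carbon gives no change at the digits printed from compound 3 to compound 4 (within the scatter) in this assay, and oxolan-3-yl in place of 1,3-oxazol-4-yl gives no change at the digits printed from compound 2 to compound 4 (within the scatter). This carbonyl carbon therefore carries three different rings, one of them joined through its nitrogen and two through carbon, and all three read alike on this measure of oral bioavailability. No measurement shown gives a reason for this sameness.

Because all these compounds sit at the same printed value, they do not show which change at this position, if any, would move the read-out. A carboxylic acid, a basic amine or a longer open chain on this carbonyl carbon remains an open case.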